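This account rests on a few compounds, and the source may have more. Where it says the series, first, only, none or still open, it means among the compounds named here.

Compound 1 `COc1ccc(Nc2nc(N)c(C(=O)c3ccccc3)s2)cc1`: 230 nM
Compound 2 `COc1ccc(C(=O)c2sc(Nc3ccc(Cl)cc3)nc2N)cc1`: > 10000 nM

In a functional assay on MOLT-4 cells (Homo sapiens) for antiproliferative activity, read by cell counting, with a stated time of 2 days (on this read-out lower numbers stand for stronger inhibition and higher numbers for weaker inhibition), compound 1 gives 230 nM. For compound 2 the assay reports only a limit, > 10000 nM, so compound 2 stands at the limit of > 10000 nM in this assay, at which 1 of the 2 values shown sits, and no number is known for it. Compound 3 `Nc1nc(Nc2ccc(Cl)cc2)sc1C(=O)c1ccccc1` is compound 2 with hydrogen in place of methoxy on an aromatic carbon. Since compound 2 sits at a limit, the size of the step cannot be read from the data; still, a move toward stronger inhibition is expected, with the expected step of an at least 4.0-fold lower number from compound 2 to compound 3 (0.60 log units; beyond the scatter) likely exceeding the usual scatter. Compound 3 is estimated at 2500 nM, within a range from 400 nM to 10000 nM.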

Compound 3, half-maximal inhibitory concentration: > 10000 nM
Compound 3 gave a limit, no number; the forecaster's own chance of this, stated with the estimate: 35%; middle value at least 4.0-fold (0.60 log units) from the limit.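

In this assay, going by these compounds alone, chloro in place of methoxy on an aromatic carbon gives an at least 43-fold higher number from compound 1 to compound 3 (1.63 log units; beyond the scatter), the first readable step in this set, and it shows that this single change is enough to lose the activity of compound 1. Compound 3, like compound 2, stands only at a limit, so the step for 4-methoxyphenyl to phenyl cannot be read: the limit of > 10000 nM in this assay, at which 2 of the 3 values shown sit.

As far as these compounds go, it remains open whether a different group at the chloro position, such as a hydroxyl or an amine, would keep the activity of compound 1. From the compounds shown here alone, it is also open whether 4-methoxyphenyl in place of phenyl would matter with the methoxy of compound 1 kept.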